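The source may hold more compounds than are shown below. What is called first, only, known or untested is meant among the compounds shown, and "the series" means these compounds.

Measured in a functional assay on COR-L23 cells (Homo sapiens) for antiproliferative activity, read by CellTiter-Glo, with a stated time of 72 h; a lower number here means a stronger inhibitor, a higher number a weaker inhibitor:
- compound 1 `C[C@@H](c1ccc(NC(=O)N2CC(c3cccnc3)C2)cc1)N1Cc2ccccc2C1=O` gives 8 nM
- compound 2 `C[C@H](NC(=O)c1cccc(F)c1)c1ccc(NC(=O)N2CC(c3cccnc3)C2)cc1` gives 10 nM
- compound 3 `C[C@H](NC(=O)C1CCOCC1)c1ccc(NC(=O)N2CC(c3cccnc3)C2)cc1` gives 58 nM

Compound 3 stands highest of the three, the weakest so far (58 nM), with a 7.3-fold higher number from compound 1 to compound 3 (0.86 log units; beyond the scatter) and a 5.8-fold higher number from compound 2 to compound 3 (0.76 log units; beyond the scatter). The next compound is compound 4 `C[C@H](NC(=O)[C@@H]1CCCN1C)c1ccc(NC(=O)N2CC(c3cccnc3)C2)cc1`, with the change (1-methylpyrrolidin-2-yl in place of oxan-4-yl on a carbonyl carbon). In words, 1-methylpyrrolidin-2-yl replaces oxan-4-yl on a carbonyl carbon. Among the measured compounds shown here, the closest precedent is the swap at that same place, a 5.8-fold higher number from compound 2 to compound 3 (0.76 log units; beyond the scatter), a modest step. The step of a 1.3-fold higher number from compound 1 to compound 2 (0.10 log units; within the scatter) shows that two different groups can give values within the scatter of each other. For the measured compounds named here, no measured step exchanges one non-aromatic ring for another, so the precedent is only indirect. In this assay a small step is therefore expected, with a slight lean towards a higher number and no firm expectation of leaving the scatter. The expected step is a 1.7-fold higher number from compound 3 to compound 4 (0.24 log units; within the scatter). For compound 4 the estimated value is 100 nM, with an expected range from 30 nM to 350 nM.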

Compound 4, half-maximal inhibitory concentration: 38 nM
Compound 4: middle estimate off by 2.6-fold (0.42 log units), on the high side; low and high end bracket the measured number.
By their numbers in this assay, from the lowest: compounds 1 and 2 (each within the scatter of the next); then compounds 4 and 3 (each within the scatter of the next).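

In this assay, the swap on this carbonyl carbon gives a 1.5-fold lower number from compound 3 to compound 4 (0.18 log units; within the scatter) and so separates neither the six-membered oxygen ring from the five-membered nitrogen ring, nor the defined stereocentre of 1-methylpyrrolidin-2-yl from its absence in oxan-4-yl. The new group still trails the aromatic groups, with a 3.8-fold higher number from compound 2 to compound 4 (0.58 log units; beyond the scatter) against 3-fluorophenyl and a 4.8-fold higher number from compound 1 to compound 4 (0.68 log units; beyond the scatter) against the group of compound 1, so among these four compounds those carrying a six-membered aromatic ring of carbon keep the lower numbers, with no exception. Nothing at hand bears on why these steps have the sizes they do.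

Open, on these data alone, is whether the ring in 1-methylpyrrolidin-2-yl matters at all, which an open-chain dimethylaminomethyl group at the same carbonyl carbon would test. Also open, as far as these compounds go, are the opposite stereocentre and a pyridine ring at this place.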